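Fluoro added to the core phenyl of compound 2

The source may hold more compounds than are shown below. What is called first, only, known or untested is meant among the compounds shown, and "the series" means these compounds.

The series shares one core, carrying a triazole linked through a benzyl group that is varied. Compound 1 `O=C(NCc1cn(Cc2ccc(F)cc2)nn1)c1cn(-c2ccccc2)nc1-c1ccccc1` bears a 4-fluorophenyl there and in a functional assay on HeLa cells (Homo sapiens) for antiproliferative activity, read by sulforhodamine B assay, with a stated time of 48 h (on this read-out lower numbers stand for stronger inhibition of growth and higher numbers for weaker inhibition of growth), compound 1 gives 1600 nM. Compound 2 `O=C(NCc1cn(Cc2ccc(C(F)(F)F)cc2)nn1)c1cn(-c2ccccc2)nc1-c1ccccc1` carries a 4-(trifluoromethyl)phenyl instead and in this assay compound 2 gives 1600 nM, so that the step of no change at the digits printed from compound 1 to compound 2 (within the scatter) lies within the scatter. Among the measured compounds shown here, compound 3 `COc1ccc(Cn2cc(CNC(=O)c3cn(-c4ccccc4)nc3-c3ccccc3)nn2)cc1OC` carries a 3,4-dimethoxyphenyl and in this assay compound 3 gives 10800 nM; the step of a 6.8-fold higher number from compound 2 to compound 3 (0.83 log units; beyond the scatter) is the only change beyond the scatter among the three. Compound 2 thus stands level with compound 1 and together they give the lowest numbers of the three.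

Compound 4 `O=C(NCc1cn(Cc2ccc(C(F)(F)F)cc2)nn1)c1cn(-c2ccccc2)nc1-c1ccc(F)cc1` differs from compound 2 by fluoro in place of hydrogen on an aromatic carbon, on a phenyl attached to the core and not on the benzyl group. For the measured compounds named here, no measured step touches this ring; the only step on a distant ring, no change at the digits printed from compound 1 to compound 2 (within the scatter), was within the scatter. A step within the scatter is therefore expected, no change at the digits printed from compound 2 to compound 4 (within the scatter). Compound 4 is estimated at 1600 nM, between 700 nM and 3600 nM.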

Compound 4, concentration for 50% growth inhibition: 250 nM
Estimate against measurement, compound 4: 6.4-fold (0.81 log units) above; measured number below the stated range.
By their numbers in this assay, from the lowest: compound 4; then compounds 1 and 2 (each within the scatter of the next); then compound 3.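

The phenyl on the shared core, which stayed the same in compounds 1 to 3, proves to matter in this assay: the change from phenyl to 4-fluorophenyl gives a 6.4-fold lower number from compound 2 to compound 4 (0.81 log units; beyond the scatter). Among the compounds shown here, all the earlier steps lay on the benzyl group, so this is the first sign that the number also depends on this distant ring, and that a single added fluoro is enough to move it beyond the scatter. Nothing measured here accounts for this step.

As far as these compounds go, whether the drop belongs to fluoro itself or would also follow with chloro, methyl or methoxy in the same place remains open. From the compounds shown here alone, it is also open whether the same fluoro would lower the number alongside the 4-fluorophenyl of compound 1 or the 3,4-dimethoxyphenyl of compound 3.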